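Pyridyl Dithiocarbamate Benzamides in a Cell Growth Assay

The source may report more compounds than this note shows. Statements on the series, on what has been measured and on what is new or still open speak of the compounds shown alone.

Measured compounds:
compound 1, `CN(C(=S)SCc1ccc(C(=O)Nc2ccccc2N)cc1)c1cccnc1`, 70.5%;
compound 2, `N#Cc1ccc(N2CCN(C(=S)SCc3ccc(C(=O)Nc4ccccc4N)cc3)CC2)cc1`, 70.6%;
compound 3, `Nc1ccccc1NC(=O)c1ccc(CSC(=S)N(Cc2ccccc2)Cc2ccccc2)cc1`, 18.9%.

In a functional assay on HeLa cells (Homo sapiens) for antiproliferative activity, read by CCK-8 assay, with a stated time of 72 h, tested at 8 uM (a lower number here means a weaker effect, a higher number a stronger effect of the compound at the concentration tested), compound 1 gives 70.5%, the second highest of the three numbers. Its nearest neighbour is compound 2, whose 70.6% lies within the scatter of repeated measurements, so the two cannot be told apart. Among the measured compounds shown here, compound 3 stands far away with 18.9%, a gap well beyond the scatter; no single step connects it to compound 1, so only the two values themselves can be compared.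

Compound 4, `CN(Cc1ccncc1)C(=S)SCc1ccc(C(=O)Nc2ccccc2N)cc1`, has not yet been measured. It differs from compound 1 in one place: (pyridin-4-yl)methyl in place of pyridin-3-yl on an amide-type nitrogen. For the measured compounds named here, no step between measured compounds describes this change, so the expectation rests on the three numbers alone. Going by the values given here, compound 4 is expected to land below compound 1 by a moderate step, a number 15.5 percentage points lower from compound 1 to compound 4 (beyond the scatter), possibly beyond the scatter, because compound 3, the only compound carrying a benzyl-type group on that nitrogen, gives 18.9%. The estimate for compound 4 is 55%, with a range from 25% to 78%.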

Compound 4, a percentage reported as inhibition, at one concentration (the size of the read-out at that concentration, not a potency): 72.7%
For compound 4 the middle estimate is 17.7 percentage points below the measured one; low and high end bracket the measured number.
By their numbers in this assay, from the lowest: compound 3; then compounds 1, 2 and 4 (each within the scatter of the next).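

Putting (pyridin-4-yl)methyl in place of pyridin-3-yl on the amide-type nitrogen gives, in this assay, a number 2.2 percentage points higher from compound 1 to compound 4 (within the scatter), so compound 1 and compound 4 cannot be told apart. Among the compounds shown here, this is the first single-place comparison at this position. It shows that the read-out holds when the pyridine ring is attached to this nitrogen through a saturated chain carbon rather than directly, and that a group of this kind on the nitrogen can go with a strong effect at the concentration tested.

The change alters both the link and the place of the ring nitrogen, and the compounds shown do not separate the two, since neither (pyridin-3-yl)methyl nor pyridin-4-yl appears among them. They also leave open how a 2-(dimethylamino)ethyl group or a carboxylic acid on this nitrogen would read.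

No measurement at hand explains why the read-out holds across this change.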